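Side-chain swaps on a shared core

A few compounds are considered here, and "the series" means these few. Any claim that something is new, unique, unknown or untested is made for them only; others in the source may bear on it.

Measured so far in a functional assay on SK-MEL-2 cells (Homo sapiens) for cytotoxicity, read by sulforhodamine B assay (a higher number here means a weaker inhibitor, a lower number a stronger inhibitor), as follows
- compound 1 `COCCNc1nc(-c2ccccc2)nc2ccccc12` gives 27.6 ug/mL
- compound 2 `CN1CCCN(c2nc(-c3ccccc3)nc3ccccc23)CC1` gives 36.6 ug/mL

Compound 2 lies within the scatter of compound 1, so the pair gives no ranking. Going to compound 3 `COC(=O)CNc1nc(-c2ccccc2)nc2ccccc12` puts ((methoxycarbonyl)methyl)amino in place of 4-methyl-1,4-diazepan-1-yl on an aromatic carbon, with ((methoxycarbonyl)methyl)amino in place of 4-methyl-1,4-diazepan-1-yl on an aromatic carbon as the counted difference. For the measured compounds named here, the one measured step bearing on this is a 1.3-fold higher number from compound 1 to compound 2 (0.12 log units; within the scatter) for an exchange on the same aromatic carbon. The estimate is a 1.2-fold lower number from compound 2 to compound 3 (0.09 log units; within the scatter) in this assay and so no expected shift beyond the scatter. Compound 3 is expected at 30 ug/mL with an estimated range from 14 ug/mL to 60 ug/mL around it.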

Compound 3, half-maximal inhibitory concentration: 37.6 ug/mL
For compound 3 the middle estimate is 1.3-fold (0.10 log units) below the measured one; low and high end bracket the measured number.
By their numbers in this assay, from the lowest: compounds 1, 2 and 3 (each within the scatter of the next).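

In this assay the new side chain gives a 1.0-fold higher number from compound 2 to compound 3 (0.01 log units; within the scatter) and a 1.4-fold higher number from compound 1 to compound 3 (0.13 log units; within the scatter) so it cannot be told apart from either earlier compound. At this aromatic carbon, ring-free ((methoxycarbonyl)methyl)amino is not separated from the 4-methyl-1,4-diazepan-1-yl ring, and on the chain methoxycarbonyl is not separated from methoxymethyl. No evidence is available that bears on this result. Still open, on these data alone, is whether a carboxylic acid or a longer chain at this carbon would move the number beyond the scatter.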